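Methyl for chloro in a benzyloxyphenyl isoxazoline series

A few compounds are considered here, and "the series" means these few. Any claim that something is new, unique, unknown or untested is made for them only; others in the source may bear on it.

Measured so far in an ADME assay on Vero cells (Chlorocebus sabaeus) for cytotoxicity, read by microscopy, with a stated time of 3 days; a lower number here means that less compound is tolerated, a higher number that more compound is tolerated:
Compound 1 `c1ccc(COc2ccc(C3CC(c4ccccc4)=NO3)cc2)cc1` gives > 100 ug/mL, a limit of the assay.
Compound 2 `Brc1ccc(C2=NOC(c3ccc(OCc4ccccc4)cc3)C2)cc1` gives >= 20 ug/mL, a limit of the assay.
Compound 3 `Clc1ccc(C2=NOC(c3ccc(OCc4ccccc4)cc3)C2)cc1` gives > 100 ug/mL, a limit of the assay.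

Compound 3 stands at the higher of the two limits, shared with compound 1 as the limit of > 100 ug/mL in this assay, at which 2 of the 3 values shown sit, shows, while the limit of >= 20 ug/mL in this assay, at which 1 of the 3 values shown sits, marks the other. The steps a step that the two limits leave unreadable from compound 1 to compound 2, a step that the two limits leave unreadable from compound 1 to compound 3 and a step that the two limits leave unreadable from compound 2 to compound 3 give no readable size. Compound 4 `Cc1ccc(C2=NOC(c3ccc(OCc4ccccc4)cc3)C2)cc1` differs from compound 3 by methyl in place of chloro on an aromatic carbon. With no readable step to lean on, compound 4 is expected to stay near the same limit in this assay, so the step of a number no higher from compound 3 to compound 4 (the limit leaves the size open) is estimated as none beyond the scatter. The estimate for compound 4 is 100 ug/mL, between 40 ug/mL and 200 ug/mL.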

Compound 4, minimum cytotoxic concentration: > 100 ug/mL
Compound 4 ended at the assay's limit; the forecaster's own chance of this, stated with the estimate: 75%; the middle value lies on the limit itself.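

In this assay, among these compounds, compound 4 gives only a limit, so no step linking it to compound 1, compound 2 or compound 3 can be read. The compounds shown leave open whether these single aromatic changes alter tolerance at all.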